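The source may report more compounds than this note shows. Statements on the series, on what has been measured and on what is new or still open speak of the compounds shown alone.

Measured so far: compound 1, `S=C(N/N=C/c1ccc2ccccc2n1)Nc1cccc(Cl)c1`, gives 61300 nM; compound 2, `FC(F)(F)c1ccccc1NC(=S)N/N=C/c1ccc2ccccc2n1`, gives 20700 nM; compound 3, `Cc1ccc(NC(=S)N/N=C/c2ccc3ccccc3n2)cc1`, gives 92900 nM, all in a functional assay on SGC-7901 cells (Homo sapiens) for antiproliferative activity, read by sulforhodamine B assay, with a stated time of 72 h; a higher number here means a weaker inhibitor, a lower number a stronger inhibitor.

Compound 3 stands highest of the three numbers. Among the measured compounds shown here, its nearest neighbour is compound 1, and the only step recorded between measured compounds, a 1.5-fold higher number from compound 1 to compound 3 (0.18 log units; within the scatter), is within the scatter, so compounds 1 and 3 cannot be ordered. For the measured compounds named here, compound 2 is further away, beyond the scatter, but no single-place step links it to compound 3 or to compound 4, so its value shows only that another aryl group on the same nitrogen can sit lower.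

Compound 4, `COc1ccccc1NC(=S)N/N=C/c1ccc2ccccc2n1`, differs from compound 3 in one place: 2-methoxyphenyl in place of 4-methylphenyl on an amide-type nitrogen. Going by the values given here, the one step that bears on it, the exchange of one aryl group for another on this nitrogen, was within the scatter, which argues for a small step in this assay; the lower value of compound 2 leaves room for a modest decrease. On balance the number for compound 4 is expected to move by a 1.9-fold lower number from compound 3 to compound 4 (0.27 log units; within the scatter). For compound 4 the estimate is 50000 nM, with a range from 15000 nM to 150000 nM.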

Compound 4, half-maximal inhibitory concentration: > 100000 nM
Compound 4: no number, only a limit; the forecaster's own chance of this, stated with the estimate: 15%; at least 2.0-fold (0.30 log units) between middle value and limit.
By their numbers in this assay, from the lowest: compound 2; then compounds 1 and 3 (each within the scatter of the next). At a limit, above all of these: compound 4.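

Compound 4 gives no number in this assay, only a limit: the limit of > 100000 nM in this assay, at which 1 of the 4 values shown sits. Among the compounds shown here, the change of methoxy for trifluoromethyl on an aromatic carbon gives an at least 4.8-fold higher number from compound 2 to compound 4 (0.68 log units; beyond the scatter), the first step between compounds differing in one place that lies beyond the scatter, so the group on this aromatic carbon can shift the value measurably. The other two steps, an at least 1.0-fold higher number from compound 3 to compound 4 (0.03 log units; that floor lies within the scatter) and an at least 1.6-fold higher number from compound 1 to compound 4 (0.21 log units; that floor lies within the scatter), have floors within the scatter, so 2-methoxyphenyl is not yet separated from 4-methylphenyl or 3-chlorophenyl on the amide-type nitrogen, and the true size of these steps stays unfixed.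

The compounds shown leave open how far the value of compound 4 lies past its limit, and they give no cause for the step from compound 2. An amine or a carboxylic acid on the same aromatic carbon, or a longer alkoxy chain in place of methoxy, would show whether trifluoromethyl stands alone in giving the lowest value of the set or is one of several groups that do so.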